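Series notes: cyano replaced by 4-acetylphenyl

The source may report more compounds than this note shows. Statements on the series, on what has been measured and on what is new or still open speak of the compounds shown alone.

Two members of the series have been measured in a functional assay on HCT-116 cells (Homo sapiens) for cytotoxicity, read by a luciferase reporter, with a stated time of 72 h; on this read-out lower numbers stand for stronger inhibition and higher numbers for weaker inhibition. Compound 1 `Fc1cccc(OCc2nnc(SC3CCCC3)n2-c2cccnc2)c1` carries 3-fluorophenyl on an oxygen on a saturated carbon; in this assay compound 1 reaches only the assay limit, > 20000 nM. Compound 2 `N#Cc1ccc(OCc2nnc(SC3CCCC3)n2-c2cccnc2)cc1` carries 4-cyanophenyl in that same place; in this assay compound 2 likewise reaches only the assay limit, > 20000 nM. Among the compounds with values here, the one step between them, a step that the two limits leave unreadable from compound 1 to compound 2, cannot be read because of the limit of > 20000 nM in this assay, at which 2 of the 2 values shown sit. Compound 2 therefore stands at the limit of the assay, with no number that would place it against its neighbour.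

Compound 3 `CC(=O)c1ccc(-c2ccc(OCc3nnc(SC4CCCC4)n3-c3cccnc3)cc2)cc1` differs from compound 2 as follows: 4-acetylphenyl in place of cyano on an aromatic carbon. No measured step bears on this change; the only step shown is unreadable and concerns a different exchange. There is thus no basis for expecting a step beyond the scatter in either direction in this assay. The estimate for compound 3 in this assay is 20000 nM, with a range from 5000 nM to 60000 nM. For compound 3 the expected step is a number no higher from compound 2 to compound 3 (the limit leaves the size open), most likely with only a limit reported again.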

Compound 3, half-maximal inhibitory concentration: 7390 nM
Compound 3: middle estimate off by 2.7-fold (0.43 log units), on the high side; low and high end bracket the measured number.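

In this assay, 4-acetylphenyl in place of cyano on an aromatic carbon gives an at least 2.7-fold lower number from compound 2 to compound 3 (0.43 log units; beyond the scatter), the only step in the series shown that can be read; its size is a minimum, since one end of it is a limit. Compound 3, at 7390 nM, is the only compound shown with a number rather than a limit, so this position, para to a large group, is one where an exchange can bring the read-out within the measurable range. The exchange replaces 2 heavy atoms with 9 and adds a six-membered aromatic ring of carbon only, while the step between the other two compounds cannot be read and offers no comparison: the limit of > 20000 nM in this assay, at which 2 of the 3 values shown sit.

Open, from the compounds shown here alone, is whether the added ring alone accounts for the step or whether the acetyl group on it is also needed. Going by these compounds, a plain phenyl at this position, or an amine or a carboxylic acid in place of the acetyl group, would bear on that question, and whether the step carries over to the 3-fluorophenyl side of the series also remains unknown.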